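Removing a Methyl: Expected Effect on Mouse Clearance

The source may report more compounds than this note shows. Statements on the series, on what has been measured and on what is new or still open speak of the compounds shown alone.

Measured compounds:
- compound 1, `O=C(c1sc2c([N+](=O)[O-])cc(C(F)(F)F)cc2[n+]1[O-])N1CCCCC1`: "not determined" (no result reported) in an ADME assay on the whole organism for pharmacokinetics, with Mus musculus as the target; on this read-out higher numbers stand for fast clearance and lower numbers for slow clearance
- compound 2, `Cc1c(C(F)(F)F)cc2nc(C3=N[C@H](C(=O)N4CCCC4)CO3)sc2c1[N+](=O)[O-]`: 83.5 mL/min/kg

Two compounds were submitted to this assay. Compound 1 returned no result at all. Within the data shown here, compound 2 gives 83.5 mL/min/kg in this assay, and since this is the only number in hand, there is nothing within the set to place it against as high or low.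

Compound 3, with the structure `O=C([C@@H]1COC(c2nc3cc(C(F)(F)F)cc([N+](=O)[O-])c3s2)=N1)N1CCCC1`, has not yet been measured. It differs from compound 2 in a single spot: hydrogen in place of methyl on an aromatic carbon. Among the measured compounds shown here, no pair of measured compounds shows what such a change does in this assay, so the expectation rests on the change itself being a small one. The loss of a methyl group is expected to shift clearance by no more than the usual scatter, in no particular direction. The estimated step is a 1.0-fold lower number from compound 2 to compound 3 (0.02 log units; within the scatter). For compound 3 the expected clearance is 80 mL/min/kg, with a range from 45 mL/min/kg to 140 mL/min/kg.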

Compound 3, clearance: 49 mL/min/kg
The estimate for compound 3 lay 1.6-fold (0.21 log units) above the measured number, and the stated range covers the measured number.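

This pair gives the first measured view of this position in this assay. Replacing the methyl with hydrogen on this aromatic carbon, ortho to a nitro group and ortho to a trifluoromethyl group, gives a 1.7-fold lower number from compound 2 to compound 3 (0.23 log units; within the scatter). A step of this size cannot be told apart from the differences seen between repeated measurements, so this single pair gives no clear sign that the methyl matters for this read-out, and no measurement here bears on the reason.

Still open, going by these compounds, is what a larger or different group on the same aromatic carbon would do, such as a chlorine atom, a methoxy group or an ethyl chain. Also open, on these data alone, is whether the same swap would give a similar step in compounds carrying a carboxylic acid in place of the amide.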